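A Sulfonamide Series: From Naphthyl to tert-Butylphenyl

The source may report more compounds than this note shows. Statements on the series, on what has been measured and on what is new or still open speak of the compounds shown alone.

Of the compounds shown here, three of a shared sulfonamide core have been measured in a functional assay on BXPC-3 cells (Homo sapiens) for inhibition, read by MTT assay, with a stated time of 72 h; a lower number here means a stronger inhibitor of growth, a higher number a weaker inhibitor of growth. Compound 1 `O=S(=O)(NCCNCc1cccc2ccccc12)c1cc(C(F)(F)F)cc(C(F)(F)F)c1` gives 23000 nM, the highest of the three numbers. Compound 2 `O=S(=O)(NCCCNCc1ccc(Br)cc1)c1cc(C(F)(F)F)cc(C(F)(F)F)c1` gives 1500 nM, and compound 3 `O=S(=O)(NCCCNCc1ccc(-c2ccccc2)cc1)c1cc(C(F)(F)F)cc(C(F)(F)F)c1` gives 1700 nM. Within the data shown here, the only single-point step among them, a 1.1-fold higher number from compound 2 to compound 3 (0.05 log units; within the scatter), concerns a change that has no counterpart in the move considered here, and compounds 2 and 3 differ from compound 1 in more than one place, so only their raw values can be set side by side with compound 1.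

Compound 4 `CC(C)(C)c1ccc(CNCCNS(=O)(=O)c2cc(C(F)(F)F)cc(C(F)(F)F)c2)cc1` is compound 1 with 4-(tert-butyl)phenyl in place of naphthalen-1-yl on a saturated chain carbon bound to an amine nitrogen. Among the measured compounds shown here, no measured step bears directly on this change. What the numbers show is that compound 1 stands well apart from compounds 2 and 3, which leaves room for a lower number without any step to predict it. On that basis compound 4 is expected to sit somewhat lower than compound 1, an estimated step of a 1.9-fold lower number from compound 1 to compound 4 (0.28 log units; within the scatter), with a wide range. The estimate for compound 4 in this assay is 12000 nM, between 3000 nM and 40000 nM.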

Compound 4, concentration for 50% growth inhibition: 8800 nM
Compound 4: the middle estimate sits 1.4-fold (0.13 log units) above what was measured, within the range that was stated.
By their numbers in this assay, from the lowest: compounds 2 and 3 (each within the scatter of the next); then compound 4; then compound 1.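

Replacing naphthalen-1-yl with 4-(tert-butyl)phenyl on a saturated chain carbon bound to an amine nitrogen gives, in this assay, a 2.6-fold lower number from compound 1 to compound 4 (0.42 log units; beyond the scatter), so the number responds to a change at this place, though only modestly. The two groups have the same count of heavy atoms, all carbon, and neither has hydrogen-bond donors or acceptors; the counted difference is two aromatic rings against one. Nothing available explains why the number moved.

This single pair cannot separate the loss of the second ring from the gain of the tert-butyl group. Also open, from the compounds shown here alone, is how this assay would respond if a carboxylic acid or an amine took the place of the tert-butyl group on the ring of compound 4.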